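This account rests on a few compounds, and the source may have more. Where it says the series, first, only, none or still open, it means among the compounds named here.

Measured so far:
compound 1 `ClCc1ccc(Cn2cnc3c(Cl)ncnc32)cc1` — 70800 nM
compound 2 `ClCc1ccc(Cn2cnc3nc(Cl)nc(Cl)c32)cc1` — 5880 nM

In a functional assay on SF-539 cells (Homo sapiens) for cytotoxicity, read by sulforhodamine B assay, with a stated time of 48 h (on this read-out higher numbers stand for lower toxicity in this test and lower numbers for higher toxicity in this test), compound 1 gives 70800 nM, the highest number of the two measured. The nearest value comes from compound 2, which gives 5880 nM in this assay, a lower number lying beyond the usual scatter. Compound 2 differs from compound 1 in more than one place, so its value is only a pointer, not a clean step.

Compound 3 `ClCc1ccc(Cn2cnc3c(Cl)nc(Cl)nc32)cc1` is the next one to be tested in this assay. It differs from compound 1 by chloro in place of hydrogen on an aromatic carbon. For the measured compounds named here, no single-point step of this kind has been measured. Going by the values given here, the only guidance is that compound 2, which also carries two chloro groups on the shared core, gives a lower number than compound 1; compound 3 is expected to follow the same direction, with a step that lies beyond the scatter. The expected step is a 5.9-fold lower number from compound 1 to compound 3 (0.77 log units; beyond the scatter). Compound 3 is accordingly estimated at 12000 nM, within a range from 3500 nM to 40000 nM.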

Compound 3, concentration lethal to 50% of the cells: 56200 nM
Beside the measured number, compound 3's estimate is 4.7-fold (0.67 log units) below it; the measured number lies above the stated range.
By their numbers in this assay, from the lowest: compound 2; then compounds 3 and 1 (each within the scatter of the next).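

In this assay the series now has its first single-place step: chloro in place of hydrogen on an aromatic carbon, between two ring nitrogen atoms, gives a 1.3-fold lower number from compound 1 to compound 3 (0.10 log units; within the scatter). At this position, then, hydrogen and chloro cannot be told apart in this test, something the earlier pair could not show, as compound 1 and compound 2 differ in more than one place. No measured information on the compounds bears on this result, so the data offer no explanation for it.

As far as these compounds go, whether any other group at this position would give a number beyond the scatter stays open, for instance an amine, a methoxy group, a carboxylic acid or a longer chain in place of the hydrogen of compound 1. Also open, from the compounds shown here alone, is whether chloro in place of hydrogen at this carbon would give an equally small step on a version of the shared core carrying an amine in place of the other chloro group, as a single step at one position in one cell line says nothing about other substitution patterns.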